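Amino for Acetoxy on the Aryl Ring of Compound 1

The source may report more compounds than this note shows. Statements on the series, on what has been measured and on what is new or still open speak of the compounds shown alone.

Compound 1, `C=CC[C@H]1C[C@]2(C(C)Cc3ccc(OC)c(OC(C)=O)c3)OCOC2=CC1=O`, is the stronger of the two measured compounds: in a functional assay on M14 cells (Homo sapiens) for antiproliferative activity, with a stated time of 72 h (on this read-out higher numbers stand for weaker inhibition and lower numbers for stronger inhibition), compound 1 gives 16 nM. Compound 2, `C=CC[C@H]1C[C@]2([C@@H](C)Cc3ccc(OC)c(Cl)c3)OCOC2=CC1=O`, which differs from it in several places at once, gives 240 nM in this assay, a gap that lies beyond the usual scatter. Compound 3, `C=CC[C@H]1C[C@]2(C(C)Cc3ccc(OC)c(N)c3)OCOC2=CC1=O`, has not been measured. It differs from compound 1 by amino in place of acetoxy on an aromatic carbon, the amino group standing ortho to a methoxy group and meta to a large group. Among the measured compounds shown here, no measured pair shows this change on its own, so the size of the step is open. The acetoxy of compound 1 is replaced by a far smaller group carrying one donor, and a modest loss is expected; the estimated step from compound 1 to compound 3 is a 3.1-fold higher number from compound 1 to compound 3 (0.49 log units; beyond the scatter). Compound 3 is therefore expected to give about 50 nM in this assay, within a range from 12 nM to 200 nM.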

Compound 3, half-maximal inhibitory concentration: 49 nM
For compound 3 the middle estimate is 1.0-fold (0.01 log units) above the measured one; measured number inside the range.
By their numbers in this assay, from the lowest: compound 1; then compound 3; then compound 2.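

In this assay, among the compounds shown here, amino in place of acetoxy on this aromatic carbon, ortho to a methoxy group and meta to a large group, gives a 3.1-fold higher number from compound 1 to compound 3 (0.49 log units; beyond the scatter), the first step here that shows a single change on its own. The acetoxy is not required for activity at this position: compound 3, with one heavy atom there and a hydrogen-bond donor that the acetoxy lacks, still gives 49 nM. Nothing available here accounts for the size of this step.

As far as these compounds go, what a hydroxyl group or an acetamide would give on this carbon remains open, and with it whether the step follows from the entering amino or from the departing acetoxy. From the compounds shown here alone, it is equally open whether the exchange would give a similar step with an ethoxy group in place of the methoxy.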